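The compounds below may be only part of what the source reports. "The series", "measured", "known", "first", "only" and "open" are said of these compounds alone.

Compound 1, `O=c1nc(N2CCN(CC3CCCCC3)CC2)sc2c([N+](=O)[O-])cc(C(F)(F)F)cc12`, gives > 64 ug/mL in an ADME assay on Vero cells (Chlorocebus sabaeus) for cytotoxicity, read by MTT assay, with a stated time of 48 h (a higher number here means a weaker inhibitor, a lower number a stronger inhibitor), which is a limit of the assay rather than a number.
Compound 2, `O=c1cc(NCc2ccccc2)sc2c([N+](=O)[O-])cc(C(F)(F)F)cc12`, gives > 64 ug/mL in this assay, again a limit rather than a number.
Compound 3, `CN(Cc1ccc2c(c1)OCCO2)c1cc(=O)c2cc(C(F)(F)F)cc([N+](=O)[O-])c2s1`, gives > 64 ug/mL in this assay, once more a limit rather than a number.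

All three measured compounds sit at the limit of > 64 ug/mL in this assay, at which 3 of the 3 values shown sit. Compound 3 therefore stands nowhere in particular among them: on the numbers shown it is indistinguishable from compound 1 and compound 2, none of which gives a measurable value, so no order of strength can be read among the three. Compound 4, `O=c1cc(NCc2ccc3c(c2)OCCO3)sc2c([N+](=O)[O-])cc(C(F)(F)F)cc12`, has yet to be tested in this assay. It differs from compound 3 by hydrogen in place of methyl on a nitrogen on an aromatic ring. Within the data shown here, no step between two measured compounds exists here to guide how large an effect such a change might have on this read-out. Among the measured compounds shown here, with every value so far sitting at the limit of > 64 ug/mL in this assay, at which 3 of the 3 values shown sit, the expected step that the limit leaves unreadable from compound 3 to compound 4 is none beyond the scatter, and the most likely outcome is that compound 4 also returns only a limit. Compound 4 is estimated at 90 ug/mL, with a range from 40 ug/mL to 250 ug/mL.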

Compound 4, half-maximal inhibitory concentration: > 64 ug/mL
Compound 4 gave a limit, no number; the forecaster's own chance of this, stated with the estimate: 85%; the middle value lies beyond the limit too.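

No step can be read from compound 3 to compound 4 or from compound 2 to compound 4 in this assay, because each of these results is a limit and not a number: the limit of > 64 ug/mL in this assay, at which 4 of the 4 values shown sit.

The compounds shown leave open where any of them truly lies beyond that limit, and so whether either change, hydrogen in place of methyl or 2,3-dihydro-1,4-benzodioxin-6-yl in place of phenyl, affects this read-out at all.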